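Furan-2-yl to pyridin-2-yl in the series

This account rests on a few compounds, and the source may have more. Where it says the series, first, only, none or still open, it means among the compounds named here.

Of the compounds shown here, two on the shared core have numbers so far. In a functional assay on MDA-MB-231 cells (Homo sapiens) for cytotoxicity, read by MTT assay, with a stated time of 38 h (on this read-out higher numbers stand for weaker inhibition and lower numbers for stronger inhibition), compound 1 `CCN(CC)CCCCOc1c(-c2cc(OC)c(OC)c(OC)c2)oc2cc(OC)cc(OC)c2c1=O` gives 13000 nM, while compound 2 `COc1cc(OC)c2c(=O)c(OCC(=O)N/N=C/c3ccco3)c(-c3cc(OC)c(OC)c(OC)c3)oc2c1` gives 1860 nM, the lower of the two numbers.

Compound 3 `COc1cc(OC)c2c(=O)c(OCC(=O)N/N=C/c3ccccn3)c(-c3cc(OC)c(OC)c(OC)c3)oc2c1` differs from compound 2 in one group: pyridin-2-yl in place of furan-2-yl on a carbon with a double bond to nitrogen. In words, pyridin-2-yl stands in place of furan-2-yl on a carbon with a double bond to nitrogen. Among the measured compounds shown here, no measured step isolates this exchange. For the measured compounds named here, the only step available is a 7.0-fold lower number from compound 1 to compound 2 (0.84 log units; beyond the scatter), which is modest and replaces a whole group that ends in furan-2-yl, so it bears on the new change only loosely.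

The new change is confined to one aromatic ring, a smaller exchange than the one in a 7.0-fold lower number from compound 1 to compound 2 (0.84 log units; beyond the scatter), so no step beyond the scatter is expected in this assay. The expected step is a 1.0-fold lower number from compound 2 to compound 3 (0.01 log units; within the scatter). For compound 3 the estimated value is 1800 nM, with an expected range of 700 nM to 4500 nM.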

Compound 3, half-maximal inhibitory concentration: 9890 nM
Compound 3: middle estimate off by 5.5-fold (0.74 log units), on the low side, outside the stated range (above it).
By their numbers in this assay, from the lowest: compound 2; then compounds 3 and 1 (each within the scatter of the next).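

In this assay the aromatic ring on the carbon with a double bond to nitrogen proves not to be a silent place: the exchange of furan-2-yl for pyridin-2-yl alone gives a 5.3-fold higher number from compound 2 to compound 3 (0.73 log units; beyond the scatter) and so moves the number beyond the scatter. With pyridin-2-yl in place, the larger group on the saturated chain carbon bound to an oxygen on an aromatic ring no longer stands apart from the group with no ring, as a 1.3-fold lower number from compound 1 to compound 3 (0.12 log units; within the scatter) shows, so the earlier step of a 7.0-fold lower number from compound 1 to compound 2 (0.84 log units; beyond the scatter) holds for the group ending in furan-2-yl and not for that longer group in general. Nothing measured on hand accounts for the difference between these two rings.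

The compounds shown leave open whether the lower number goes with the five-membered ring or with the ring oxygen of furan-2-yl, a question on which thiophen-2-yl, pyrrol-2-yl or phenyl on the same carbon would bear. Also open, from the compounds shown here alone, is whether pyridin-3-yl or pyridin-4-yl would give a number like that of pyridin-2-yl or one closer to that of furan-2-yl.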